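The source may hold more compounds than are shown below. What is called first, only, known or untested is meant among the compounds shown, and "the series" means these compounds.

Measured so far in an ADME assay on a cell-free system (plasma, Rattus norvegicus) for protein binding:
- compound 1 `Cc1ccn(-c2ccc(Cn3cc(C(=O)O)c(=O)c4c(F)cccc43)cc2)n1`: 94.3%
- compound 2 `Cc1cn(-c2ccc(Cn3cc(C(=O)O)c(=O)c4c(F)cccc43)cc2)cn1`: 88.9%
- compound 3 `O=C(O)c1cn(Cc2ccc(-n3ccc4ncccc43)cc2)c2cccc(F)c2c1=O`: 93%

Compound 1 sits at the more-bound end of these three values, yet the steps a 1.2-fold higher unbound fraction from compound 1 to compound 3 (0.09 log units; within the scatter) and a 1.9-fold higher unbound fraction from compound 1 to compound 2 (0.29 log units; within the scatter) both lie within the scatter, so the three compounds are not separated in this assay.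

Compound 4 `O=C(O)c1cn(Cc2ccc(N3CCOC3=O)cc2)c2cccc(F)c2c1=O` differs from compound 1 in one place: 2-oxo-1,3-oxazolidin-3-yl in place of 3-methyl-1H-pyrazol-1-yl on an aromatic carbon. The two measured steps that bear on this swap are those in which the same ring on that aromatic carbon was exchanged, a 1.9-fold higher unbound fraction from compound 1 to compound 2 (0.29 log units; within the scatter) and a 1.2-fold higher unbound fraction from compound 1 to compound 3 (0.09 log units; within the scatter); both stayed within the scatter. The expectation for compound 4 is therefore a step a 1.8-fold higher unbound fraction from compound 1 to compound 4 (0.24 log units; within the scatter) towards a slightly higher unbound fraction, not beyond the scatter. Compound 4 is estimated at 90%, between 82% and 95%.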

Compound 4, plasma protein binding: 88.4%
Compound 4: the middle estimate sits 1.2-fold (0.06 log units) (unbound fraction) below what was measured; the measured number falls inside the stated range.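

Placing the non-aromatic 2-oxo-1,3-oxazolidin-3-yl on this aromatic carbon gives the only step here that passes the scatter in this assay, and only modestly (a 2.0-fold higher unbound fraction from compound 1 to compound 4 (0.31 log units; beyond the scatter)). This separation holds against the 3-methyl-1H-pyrazol-1-yl of compound 1 alone, as the other two steps stay within the scatter (a 1.7-fold higher unbound fraction from compound 3 to compound 4 (0.22 log units; within the scatter); a 1.0-fold higher unbound fraction from compound 2 to compound 4 (0.02 log units; within the scatter)). No measured evidence accounts for the step.

On these data alone, compound 4 loses the aromatic ring and gains a carbonyl in one change, so the share of each stays open. A pyrrolidin-1-yl ring, which has no carbonyl, on the same carbon would help to separate them.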